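Swapping methoxy for chloro on a measured HeLa antiproliferative series

The source may hold more compounds than are shown below. What is called first, only, known or untested is meant among the compounds shown, and "the series" means these compounds.

Of the compounds shown here, three sharing a core have been tested in a functional assay on HeLa cells (Homo sapiens) for antiproliferative activity, read by MTT assay, with a stated time of 72 h; on this read-out lower numbers stand for stronger inhibition and higher numbers for weaker inhibition. Compound 1 (`COc1ccc(N2C(=O)COc3ccc(-c4cnc(OC)c(NS(=O)(=O)c5ccc(F)cc5)c4)cc32)cc1`) gives 1220 nM, the lowest number of the three. Compound 3 (`COc1ncc(-c2ccc3c(c2)NC(=O)CO3)cc1NS(=O)(=O)c1ccc(F)cc1`) gives 7110 nM, and compound 2 (`COc1cccc(N2C(=O)COc3ccc(-c4cnc5ccccc5c4)cc32)c1`) gives 11400 nM. Among the compounds with values here, the only measured step that changes one place is a 5.8-fold higher number from compound 1 to compound 3 (0.77 log units; beyond the scatter); it shows that removing the 4-methoxyphenyl group from the amide-type nitrogen raises the number well beyond the scatter.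

Compound 4 (`COc1ccc(N2C(=O)COc3ccc(-c4cnc(Cl)c(NS(=O)(=O)c5ccc(F)cc5)c4)cc32)cc1`) is not yet measured. It differs from compound 1 at another place: chloro in place of methoxy on an aromatic carbon. The group sits next to the ring nitrogen and ortho to the ((4-fluorophenyl)sulfonyl)amino group, and the 4-methoxyphenyl group on the amide-type nitrogen is kept. Within the data shown here, none of the measured steps touches this position, so the step from compound 1 to compound 3 bears only indirectly, by showing the rest of the molecule behaves as in compound 1. With no direct guide, the expected change is small, of a size within or close to the scatter, in either direction.

Compound 4 is therefore estimated at about 1500 nM, with a range from 500 nM to 4500 nM. The expected step is a 1.2-fold higher number from compound 1 to compound 4 (0.09 log units; within the scatter).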

Compound 4, half-maximal inhibitory concentration: 8320 nM
Estimate against measurement, compound 4: 5.5-fold (0.74 log units) below; the measured number lies above the stated range.
By their numbers in this assay, from the lowest: compound 1; then compounds 3, 4 and 2 (each within the scatter of the next).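

In this assay the swap gives a 6.8-fold higher number from compound 1 to compound 4 (0.83 log units; beyond the scatter), so this position does not tolerate every small group, even though a methoxy group of two heavy atoms gives way to a single chlorine. Within the data shown here, this is the first measured sign that the group on this aromatic carbon, next to the ring nitrogen and ortho to the ((4-fluorophenyl)sulfonyl)amino group, affects the number. With the 4-methoxyphenyl group kept in both compounds, methoxy gives the lower number of the two groups shown here. Nothing measured here explains why the number rises.

The compounds shown carry only methoxy or chloro at this position, so it remains open whether an amine, a methyl group, an ethoxy group or plain hydrogen would give a number close to that of compound 1 or a higher one. As far as these compounds go, it is also open whether the same swap would change the number by a similar amount in compound 3, which has hydrogen on the amide-type nitrogen.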